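The compounds below may be only part of what the source reports. "The series", "measured", "known", "first", "only" and "open" are said of these compounds alone.

Working notes on the series. Going by the values given here, compound 1 `N=C(N)NCCCCNC(=O)/C=C/c1ccc2c(c1)[C@@H](C(=O)NCCCCNC(=N)N)[C@H](c1ccc(O)cc1)O2` gives the lowest number of the three measured so far: in an assay on isolated protein (Salivary gland) for displacement of a labelled ligand from Alpha-1A adrenergic receptor (Rattus norvegicus) (on this read-out higher numbers stand for weaker inhibition and lower numbers for stronger inhibition), compound 1 gives 290000 nM. Compound 3 `N=C(N)NCCCCNC(=O)/C=C/c1ccc2c(c1)[C@H](C(=O)NCCCCNC(=N)N)[C@@H](c1ccc(O)cc1)O2` sits alongside it, since compound 3 gives 310000 nM and the step of a 1.1-fold higher number from compound 1 to compound 3 (0.03 log units; within the scatter) is within the scatter. Compound 2 `N=C(N)NCCCCNC(=O)/C=C/c1ccc2c(c1)[C@@H](C(=O)NCCCCNC(=N)N)[C@@H](c1ccc(O)cc1)O2` gives 2440000 nM, a step of an 8.4-fold higher number from compound 1 to compound 2 (0.92 log units; beyond the scatter) and, from the other side, a 7.9-fold lower number from compound 2 to compound 3 (0.90 log units; beyond the scatter). All three measured steps concern stereochemistry only the fact that one of compounds 1 and 2 is drawn with a defined configuration and the other without, at the place where they differ the fact that one of compounds 1 and 3 is drawn with a defined configuration and the other without, at the place where they differ (the fact that one of compounds 2 and 3 is drawn with a defined configuration and the other without, at the place where they differ); none of them touches the atoms that change in compound 4.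

Compound 4 `N=C(N)NCCCCNC(=O)[C@@H]1c2cc(/C=C/C(=O)O)ccc2O[C@H]1c1ccc(O)cc1` differs from compound 1 by one oxygen atom in place of a group of 9 heavy atoms (5 carbon, 4 nitrogen; no ring), on a carbonyl carbon. Among the compounds with values here, no measured step bears on a change of this kind, so the expectation rests on the structural change alone and carries a wide range. The expected step is a 3.4-fold higher number from compound 1 to compound 4 (0.54 log units; beyond the scatter), towards a higher number. Compound 4 is thus estimated at 1000000 nM, within 200000 nM to 5000000 nM.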

Compound 4, half-maximal inhibitory concentration: > 100000000 nM
Compound 4: no number, only a limit; the forecaster's own chance of this, stated with the estimate: 35%; at least 100-fold (2.00 log units) between middle value and limit.
By their numbers in this assay, from the lowest: compounds 1 and 3 (each within the scatter of the next); then compound 2. At a limit, above all of these: compound 4.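

Hydroxy in place of the group of 9 heavy atoms, on the carbonyl carbon carrying the double-bonded chain carbon, is the first change in the series that goes beyond stereochemistry, and the step is large: an at least 340-fold higher number from compound 1 to compound 4 (2.53 log units; beyond the scatter). In this assay compound 4 gives only a limit, > 100000000 nM, so the full size of that step cannot be read. The stereo step an 8.4-fold higher number from compound 1 to compound 2 (0.92 log units; beyond the scatter) is much smaller, so at this place the group of 9 heavy atoms counts for more in the read-out than a single configuration does.

The compounds shown leave open which part of that group carries the effect, as an amine or a shorter chain at this carbonyl would tell. They also leave open whether a carboxylic acid at the other carbonyl would give a similar step.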